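Swapping the Cyanophenyl for Bromo-Methylphenyl at the Floor

This account rests on a few compounds, and the source may have more. Where it says the series, first, only, none or still open, it means among the compounds named here.

Measured compounds:
- compound 1 `N#Cc1ccc(-c2nc(NCCNc3ccc([N+](=O)[O-])c(N)n3)ncc2-c2ncc[nH]2)cc1`, > 0.5 h
- compound 2 `Nc1nc(NCCNc2ncc(-c3ncc[nH]3)c(-c3ccc(F)cc3Cl)n2)ccc1[N+](=O)[O-]`, > 0.5 h
- compound 3 `Nc1nc(NCCNc2ncc(-c3ncc[nH]3)c(-c3cc(F)c(Cl)cc3F)n2)ccc1[N+](=O)[O-]`, > 0.5 h

In an ADME assay on microsomes from liver (Rattus norvegicus) for metabolic stability (on this read-out higher numbers stand for a longer-lived compound and lower numbers for a shorter-lived compound), compound 1 gives > 0.5 h, which is a limit of the assay and not a number. Compound 2 gives > 0.5 h in this assay, again only a limit. Compound 3 likewise gives > 0.5 h, also a limit. All three sit at the limit of > 0.5 h in this assay, at which 3 of the 3 values shown sit, so compound 1 cannot be placed within the set beyond sharing that limit with the other two. The step that the two limits leave unreadable from compound 1 to compound 2 and the step that the two limits leave unreadable from compound 1 to compound 3 are therefore unreadable in size, as is a step that the two limits leave unreadable from compound 2 to compound 3.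

Compound 4 `Cc1ccc(-c2nc(NCCNc3ccc([N+](=O)[O-])c(N)n3)ncc2-c2ncc[nH]2)c(Br)c1` differs from compound 1 by 2-bromo-4-methylphenyl in place of 4-cyanophenyl on an aromatic carbon. The measured steps that bear on this change are the two other replacements of the 4-cyanophenyl group on the same aromatic carbon, and neither shows a readable size or direction in this assay, so nothing beyond the shared limit can be drawn from them. Compound 4 is expected to remain at that limit, with an expected step that the limit leaves unreadable from compound 1 to compound 4 that is not resolvable against the measured values. Compound 4 is estimated at 0.8 h, within a range from 0.4 h to 2 h.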

Compound 4, half-life: > 0.5 h
Compound 4: no number, only a limit (the forecaster's own chance of this, stated with the estimate: 70%); the middle value lies beyond the limit too.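

In this assay compound 4 gives > 0.5 h, which is a limit of the assay and not a number. No step between compound 4 and compound 1, compound 2 or compound 3 can be read, as all four share one limit: the limit of > 0.5 h in this assay, at which 4 of the 4 values shown sit.

The compounds shown leave open what the half-life of each compound is and whether replacing the 4-cyanophenyl group changes it.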